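Replacing a Bulky Carbamate Chain with a Small Carbamoyl

The source may hold more compounds than are shown below. What is called first, only, known or untested is meant among the compounds shown, and "the series" means these compounds.

Compound 1 `O=C(Nc1ccccc1)c1cc2cc([N+](=O)[O-])ccc2s1` is the parent of this small set. In a physicochemical assay for solubility (on this read-out higher numbers stand for higher solubility and lower numbers for lower solubility), compound 1 gives 10 ug/mL. Compound 2 `CC(C)(C)OC(=O)NCc1ccccc1NC(=O)c1cc2cc([N+](=O)[O-])ccc2s1` carries a ((tert-butoxycarbonyl)amino)methyl group on an aromatic carbon of the same core. In this assay compound 2 gives only a limit, < 5 ug/mL, and no exact number. That reading is the limit of < 5 ug/mL in this assay, at which 1 of the 2 values shown sits. The measured step therefore ran an at least 2.0-fold lower number from compound 1 to compound 2 (0.30 log units; that floor lies within the scatter), and its true size cannot be pinned down. Compound 3 `NC(=O)c1ccccc1NC(=O)c1cc2cc([N+](=O)[O-])ccc2s1` comes next. Its change from compound 2 is carbamoyl in place of ((tert-butoxycarbonyl)amino)methyl on an aromatic carbon. Going by the values given here, only one measured step bears on it: because the step of an at least 2.0-fold lower number from compound 1 to compound 2 (0.30 log units; that floor lies within the scatter) went down as that large group came in, taking it away again and leaving a far smaller group is expected to push the number back up, an estimated at least 1.6-fold higher number from compound 2 to compound 3 (0.20 log units; that floor lies within the scatter). Compound 3 is thus expected to sit near 8 ug/mL, somewhere between 3 ug/mL and 25 ug/mL.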

Compound 3, solubility: 10 ug/mL
Compound 3: the middle estimate sits 1.3-fold (0.10 log units) below what was measured, and the stated range covers the measured number.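

In this assay, putting carbamoyl in place of hydrogen on this aromatic carbon gives no change at the digits printed from compound 1 to compound 3 (within the scatter), so a group on this carbon can leave the reading where the parent has it. Exchanging the ((tert-butoxycarbonyl)amino)methyl group for carbamoyl at the same place gives an at least 2.0-fold higher number from compound 2 to compound 3 (0.30 log units; that floor lies within the scatter), and that figure is only a floor for the true size of the step. The reading of compound 2 is a limit and not an exact number: the limit of < 5 ug/mL in this assay, at which 1 of the 3 values shown sits.

On these data alone, whether other groups on this carbon, such as an amine, a carboxylic acid or a longer chain, would also leave the reading unchanged stays open. Also open, as far as these compounds go, are the true size of the step away from the carbamate chain and whether the same swap would behave alike elsewhere on the shared core.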